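The source may hold more compounds than are shown below. What is called first, only, known or untested is meant among the compounds shown, and "the series" means these compounds.

Three carbamates sharing one core were compared in an ADME assay for metabolic stability, read by HPLC, at pH 7; a lower number here means that the compound disappears faster, a higher number that the compound lasts longer. Compound 1 `CCCCNC(=O)Oc1ccc(Cl)cc1C(=O)Nc1cccc(Cl)c1` gives 64 h in this assay. Compound 2 `CCCCCNC(=O)Oc1ccc(Cl)cc1C(=O)Nc1cccc(Cl)c1` gives 64 h, and compound 3 `CCCCCCCCCCNC(=O)Oc1ccc(Cl)cc1C(=O)Nc1cccc(Cl)c1` gives 64 h. The step of no change at the digits printed from compound 1 to compound 2 (within the scatter) rests on (methyl in place of hydrogen on a saturated chain carbon, four bonds along the chain from an amide-type nitrogen), and the step of no change at the digits printed from compound 1 to compound 3 (within the scatter) rests on (hexyl in place of hydrogen on a saturated chain carbon, four bonds along the chain from an amide-type nitrogen), which is also how the core of compound 3 differs from the core of compound 1; the step of no change at the digits printed from compound 2 to compound 3 (within the scatter) completes the picture. Compound 4 `CCCCCCCCCCCNC(=O)Oc1ccc(Cl)cc1C(=O)Nc1cccc(Cl)c1` is not yet measured in this assay. It differs from compound 3 by methyl in place of hydrogen on a saturated chain carbon, ten or more bonds along the chain from an amide-type nitrogen. For the measured compounds named here, this is the same kind of change as the one from compound 1 to compound 2, but the place is not the same: there the methyl enters four bonds along the chain from an amide-type nitrogen, here at the place named in the difference just given. Since lengthening the chain left compound 1, compound 2 and compound 3 level within the scatter, compound 4 is expected to show a step of no change at the digits printed from compound 3 to compound 4 (within the scatter) in this assay. Compound 4 is therefore estimated at 64 h, between 32 h and 128 h.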

Compound 4, half-life: 64 h
Estimate against measurement, compound 4: no gap at the digits printed, and the stated range covers the measured number.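

In this assay, methyl in place of hydrogen on a saturated chain carbon gives no change at the digits printed from compound 3 to compound 4 (within the scatter), and set beside the earlier step on another core, the result is the same: the same change on two cores in this assay, no change at the digits printed (within the scatter) from compound 1 to compound 2 and no change at the digits printed (within the scatter) from compound 3 to compound 4, 1.0-fold (0.00 log units) apart, within the scatter of two such steps. The longer additions read alike, with no change at the digits printed from compound 2 to compound 4 (within the scatter) and no change at the digits printed from compound 1 to compound 4 (within the scatter), and the hexyl change also agrees when carried from one core to another: the same change on two cores in this assay, no change at the digits printed (within the scatter) from compound 1 to compound 3 and no change at the digits printed (within the scatter) from compound 2 to compound 4, 1.0-fold (0.00 log units) apart, within the scatter of two such steps. This shows that these chain extensions carry between the cores of compounds 1 to 4 without a detectable difference in this assay, but as every step is flat, it does not show that a change with a real effect on half-life would carry over in the same way.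

The compounds shown leave open whether a chain ending in an amine or a carboxylic acid, or a branched chain, would stay level with these four in this assay. They also leave open how a methyl or ethyl chain, shorter than that of compound 1, would read.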